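Swapping 3-methoxyphenyl for 4-acetylphenyl at the assay limit

This account rests on a few compounds, and the source may have more. Where it says the series, first, only, none or still open, it means among the compounds named here.

Compound 1 `O=C(CCc1cccc2c1B(O)OC2)Nc1ccc(Cl)cc1` gives 5000 nM
Compound 2 `COc1cccc(-c2cccc(NC(=O)CCc3ccc4c(c3)COB4O)c2)c1` gives > 100000 nM

In a functional assay on SK-OV-3 cells (Homo sapiens) for antiproliferative activity, read by MTT assay, with a stated time of 72 h (on this read-out higher numbers stand for weaker inhibition and lower numbers for stronger inhibition), compound 1 gives 5000 nM as a measured number. Compound 2 gives > 100000 nM in this assay and this is a limit of the assay, not a number. The pair thus holds the limit of > 100000 nM in this assay, at which 1 of the 2 values shown sits, and so compound 2 has no exact position on the scale.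

Compound 3 `CC(=O)c1ccc(-c2cccc(NC(=O)CCc3ccc4c(c3)COB4O)c2)cc1` has not yet been measured. It differs from compound 2 at one place, given by 4-acetylphenyl in place of 3-methoxyphenyl on an aromatic carbon and in words 4-acetylphenyl in place of 3-methoxyphenyl on an aromatic carbon, meta to a large group. Within the data shown here, no measured step in this small set shows what such a swap does, so the expectation rests on compound 2 alone. The expected step of an at least 1.4-fold lower number from compound 2 to compound 3 (0.15 log units; that floor lies within the scatter) in this assay is small, toward stronger inhibition if it shows at all, and it may stay within the scatter. For compound 3 the estimate is 70000 nM with an expected range of 15000 nM to 200000 nM and the result may well come back as a limit only.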

Compound 3, half-maximal inhibitory concentration: 79000 nM
Beside the measured number, compound 3's estimate is 1.1-fold (0.05 log units) below it, within the range that was stated.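

In this assay compound 3 gives 79000 nM, so this position now carries a group with a measured number on the scale, which compound 2 did not provide. Putting 4-acetylphenyl in place of 3-methoxyphenyl on an aromatic carbon, meta to a large group, gives an at least 1.2-fold lower number from compound 2 to compound 3 (0.10 log units; that floor lies within the scatter); only a floor for this step is known, so the change may be larger than that floor or may not exceed the usual scatter. The true size of the step stays unfixed, as one end of it is still only a limit of the assay and not a number: the limit of > 100000 nM in this assay, at which 1 of the 3 values shown sits.

The compounds shown leave open whether the acetyl group itself or its place on the phenyl ring accounts for the step, as 4-acetylphenyl and 3-methoxyphenyl differ in both the group they carry and where they carry it. They also leave open how this position would read in this assay with a carboxylic acid or an amine in place of the acetyl group.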